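Two Chlorines on a Purine Core Against Colon Cancer Cells

The source may report more compounds than this note shows. Statements on the series, on what has been measured and on what is new or still open speak of the compounds shown alone.

Compound 1, `CCCCC(CCO)n1cnc2c(Cl)ncnc21`: in a functional assay on HCT-116 cells (Homo sapiens) for antiproliferative activity, read by MTT assay, with a stated time of 48 h (a lower number here means a stronger inhibitor, a higher number a weaker inhibitor), compound 1 gives > 50000 nM, which is a limit of the assay and not a number.
Compound 2, `CCCCC(CCO)n1cnc2cncnc21`: in this assay compound 2 gives > 50000 nM, again a limit rather than a number.
Compound 3, `CCCCCCCC(CCO)n1cnc2c(Cl)ncnc21`: in this assay compound 3 gives 4160 nM.

Among the measured compounds shown here, compound 3 thus carries the only measured number; the other two values rest at the limit of > 50000 nM in this assay, at which 2 of the 3 values shown sit. The change from compound 2 to compound 1 is chloro in place of hydrogen on an aromatic carbon, and because both values are limits it gives a step that the two limits leave unreadable from compound 2 to compound 1. The change from compound 1 to compound 3, propyl in place of hydrogen on a saturated chain carbon, five bonds along the chain from an aromatic nitrogen, gives an at least 12-fold lower number from compound 1 to compound 3 (1.07 log units; beyond the scatter).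

Compound 4, `CCCCCCCC(CCO)n1cnc2c(Cl)nc(Cl)nc21`, is not yet measured. It differs from compound 3 by chloro in place of hydrogen on an aromatic carbon. This is the same kind of change as from compound 2 to compound 1, though the place differs: in compound 1 the chloro sits next to the ring nitrogen, ortho to a fused ring, meta to a fused ring, opposite the ring nitrogen, whereas in compound 4 it sits between two ring nitrogen atoms, meta to a chloro group, meta to a fused ring, para to a fused ring. How the cores of compound 2 and compound 3 differ is not broken down here.

Since the earlier step of this kind is unreadable, the expectation rests on compound 3 and its 4160 nM alone, and a modest step of a 2.1-fold lower number from compound 3 to compound 4 (0.32 log units; beyond the scatter) is estimated. Compound 4 is expected to give about 2000 nM, estimated to lie between 500 nM and 15000 nM.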

Compound 4, half-maximal inhibitory concentration: 12800 nM
The estimate for compound 4 lay 6.4-fold (0.81 log units) below the measured number, and the stated range covers the measured number.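

On the core of compound 3, chloro in place of hydrogen on an aromatic carbon, between two ring nitrogen atoms, gives a 3.1-fold higher number from compound 3 to compound 4 (0.49 log units; beyond the scatter), and since a higher number means a weaker inhibitor, the added chloro goes with weaker activity here. The same kind of change at a different place, from compound 2 to compound 1, cannot be read, since each of those two values is a limit and not a number: the limit of > 50000 nM in this assay, at which 2 of the 4 values shown sit. This leaves a single readable step for this change, so it shows what chloro did at one place on one core, but it does not show that the result carries over from one core to another or that added chloro weakens activity across the series.

On these data alone, whether another group at that same place, such as an amine or a methoxy group, would give a lower or a higher number than compound 3 stays open. Among the compounds shown here, also open are whether a longer chain than the one in compound 3 would lower the number further, and what would happen with a carboxylic acid in place of the alcohol at the end of the side chain.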